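The source may report more compounds than this note shows. Statements on the series, on what has been measured and on what is new or still open speak of the compounds shown alone.

Measured compounds in a functional assay on SK-HEP1 cells (Homo sapiens) for cytotoxicity, read by MTT assay, with a stated time of 48 h; a lower number here means a stronger inhibitor, a higher number a weaker inhibitor:
compound 1 `COc1cc2nc(Cl)nc(Nc3cccc(Cl)c3)c2cc1OC`: 16500 nM
compound 2 `COc1cc2nc(Cl)nc(Nc3cc(C)ccc3F)c2cc1OC`: a limit only, > 40000 nM
compound 3 `COc1cc2nc(Cl)nc(Nc3ccc(O)c(C)c3)c2cc1OC`: a limit only, > 40000 nM

Among the compounds with values here, compound 1 stands as the sole numeric value among the three; the other two sit at the limit of > 40000 nM in this assay, at which 2 of the 3 values shown sit. The two measured steps, an at least 2.4-fold higher number from compound 1 to compound 2 (0.38 log units; beyond the scatter) and an at least 2.4-fold higher number from compound 1 to compound 3 (0.38 log units; beyond the scatter), both exchanged the whole aryl group on the nitrogen and both ran toward a higher number in this assay; the step that the two limits leave unreadable from compound 2 to compound 3 cannot be read from two limits.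

Compound 4 `COc1cc2nc(Cl)nc(Nc3cccc(Oc4ccc(C#N)cc4)c3)c2cc1OC` differs from compound 1 by 4-cyanophenoxy in place of chloro on an aromatic carbon. Within the data shown here, no measured step alters this position alone, and none introduces a group of this kind, so the measured steps bear on it only loosely: each change tried at the aryl group on the nitrogen gave a weaker compound, and a large new group is a change of a different sort. The step of a 1.2-fold higher number from compound 1 to compound 4 (0.08 log units; within the scatter) is therefore expected to be small or toward weaker. For compound 4 the estimate in this assay is 20000 nM, within 7000 nM to 55000 nM, with a fair chance of a limit only.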

Compound 4, half-maximal inhibitory concentration: > 40000 nM
Compound 4 ended at the assay's limit; the forecaster's own chance of this, stated with the estimate: 30%; at least 2.0-fold (0.30 log units) between middle value and limit.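

In this assay, within the data shown here, the step of an at least 2.4-fold higher number from compound 1 to compound 4 (0.38 log units; beyond the scatter) is the first measured change at the chloro position itself, and it runs the same way as the two exchanges of the whole aryl group. Among the compounds shown, only compound 1 gives a number, 16500 nM. Every departure from its 3-chlorophenyl group tested here ends in a limit, so compound 2, compound 3 and compound 4 cannot be ordered among themselves. Compound 4 gives a limit and not a number, which leaves the size of its step with a floor only: the limit of > 40000 nM in this assay, at which 3 of the 4 values shown sit.

On these data alone, it remains open whether the ring or the nitrile of 4-cyanophenoxy goes with the higher number, a question that plain phenoxy would address. As far as these compounds go, whether a small replacement for chloro, such as fluoro, methoxy or an amine, holds the value of compound 1 also remains open.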